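This account rests on a few compounds, and the source may have more. Where it says the series, first, only, none or still open, it means among the compounds named here.

Measured in a functional assay on LoVo cells (Homo sapiens) for antiproliferative activity, read by MTT assay, with a stated time of 72 h; on this read-out higher numbers stand for weaker inhibition and lower numbers for stronger inhibition:
Compound 1 `CN1CCC(NC(=O)c2ccc(Cn3nc(-c4cnn(C)c4)c4ccccc4c3=O)cc2)CC1`: 83300 nM.
Compound 2 `Cn1cc(-c2nn(Cc3ccc(C(=O)NC4CCCC4)cc3)c(=O)c3ccccc23)cn1`: 23700 nM.
Compound 3 `Cc1noc(C)c1-c1nn(Cc2ccc(C(=O)NC3CC(C)(C)N([O])C(C)(C)C3)cc2)c(=O)c2ccccc12`: 41200 nM.

Compound 3 stands second highest of the three numbers; its value and that of compound 2 lie within the scatter of each other, while compound 1 gives a higher number. Within the data shown here, the only single-point step measured so far is a 3.5-fold lower number from compound 1 to compound 2 (0.55 log units; beyond the scatter), a change on the amide-type nitrogen. Compound 4 `Cn1cc(-c2nn(Cc3ccc(C(=O)NC4CC(C)(C)N([O])C(C)(C)C4)cc3)c(=O)c3ccccc23)cn1` keeps the amide of compound 3 and alters the aromatic group: 1-methyl-1H-pyrazol-4-yl in place of 3,5-dimethyl-1,2-oxazol-4-yl on an aromatic carbon. Among the measured compounds shown here, no measured step touches this position, so nothing here supports a shift beyond the scatter in this assay. The expected step is a 1.2-fold lower number from compound 3 to compound 4 (0.07 log units; within the scatter). Compound 4 is estimated at 35000 nM, with a range from 12000 nM to 100000 nM.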

Compound 4, half-maximal inhibitory concentration: 50100 nM
Beside the measured number, compound 4's estimate is 1.4-fold (0.16 log units) below it, within the range that was stated.
By their numbers in this assay, from the lowest: compounds 2, 3, 4 and 1 (each within the scatter of the next, the first and the last beyond it).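

In this assay, among these compounds, a 1.2-fold higher number from compound 3 to compound 4 (0.08 log units; within the scatter) is the first measured step at this aromatic carbon, and it leaves 3,5-dimethyl-1,2-oxazol-4-yl and 1-methyl-1H-pyrazol-4-yl indistinguishable in this pair. Among the compounds shown here, with 1-methyl-1H-pyrazol-4-yl held constant, the amide-type nitrogen gives a 2.1-fold higher number from compound 2 to compound 4 (0.33 log units; beyond the scatter) on one side and a 1.7-fold lower number from compound 1 to compound 4 (0.22 log units; within the scatter) on the other, so only the step from the cyclopentyl amide lies beyond the scatter. No evidence here bears on the reason for these numbers.

Still open, from the compounds shown here alone, is whether a phenyl or a carboxylic acid at this aromatic carbon would move the number beyond the scatter. Also open, going by these compounds, is how a primary amine on a longer chain would behave on the amide-type nitrogen.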